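The source may hold more compounds than are shown below. What is called first, only, known or untested is meant among the compounds shown, and "the series" means these compounds.

Within the data shown here, compound 2, `CC(C)(C)N1O[C@H](n2cc(F)c(=O)[nH]c2=O)C[C@@H]1c1ccccc1`, is one of two compounds measured so far in a functional assay on LCL cells (Homo sapiens) for cytotoxicity, read by MTT assay, with a stated time of 72 h; on this read-out lower numbers stand for stronger inhibition and higher numbers for weaker inhibition; in this assay compound 2 gives 67500 nM. The other is compound 1, `Cc1cn([C@@H]2C[C@H](c3ccccc3)N(Cc3ccccc3)O2)c(=O)[nH]c1=O`, which in this assay gives 55200 nM; the two numbers lie within the usual scatter of each other, so neither can be called the stronger. Compound 3, `Cc1cn([C@@H]2C[C@H](c3ccccc3)N(C(C)(C)C)O2)c(=O)[nH]c1=O`, is not yet measured in this assay. It differs from compound 2 by methyl in place of fluoro on an aromatic carbon, a methyl in place of fluoro on an aromatic carbon. Among the measured compounds shown here, no measured pair shows this change by itself; compound 1, which carries the methyl, gives a number close to that of compound 2, which carries the fluoro, though the two also differ elsewhere. Compound 3 is therefore expected to show a step of a 1.1-fold lower number from compound 2 to compound 3 (0.05 log units; within the scatter), not beyond the scatter in either direction. Compound 3 is estimated at 60000 nM, with a range from 25000 nM to 150000 nM.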

Compound 3, half-maximal inhibitory concentration: 87100 nM
The estimate for compound 3 lay 1.5-fold (0.16 log units) below the measured number; the measured number falls inside the stated range.
By their numbers in this assay, from the lowest: compounds 1, 2 and 3 (each within the scatter of the next).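

In this assay, among these compounds, methyl in place of fluoro on an aromatic carbon can be read by itself for the first time, and it gives a 1.3-fold higher number from compound 2 to compound 3 (0.11 log units; within the scatter), so this position does not separate the two groups on this read-out. Compound 3 also isolates a second change, tert-butyl in place of benzyl on an amine nitrogen in a ring, which gives a 1.6-fold higher number from compound 1 to compound 3 (0.20 log units; within the scatter), so neither single change moves the number beyond the usual scatter. No evidence is available that would explain these results.

The compounds shown leave open whether an amine or a nitrile on this aromatic carbon would give a number beyond the scatter of those for fluoro and methyl. They also leave open whether a longer chain on the amine nitrogen in a ring would do so.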